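The source may hold more compounds than are shown below. What is called first, only, known or untested is meant among the compounds shown, and "the series" means these compounds.

Working notes on the series.

All three compounds share one core, varied at a single position, and are compared in an assay on CHO-K1 cells for displacement of a labelled ligand from prostaglandin E2 receptor EP1 subtype (Homo sapiens), read by scintillation counting, with a stated time of 45 min; on this read-out lower numbers stand for stronger inhibition and higher numbers for weaker inhibition. Compound 1 `Cc1cc(C(=O)NC(C)C)nn1Cc1cc(Cl)cc2cc(-c3ccccc3)oc12` gives 10 nM. Compound 2 `Cc1cc(C(N)=O)nn1Cc1cc(Cl)cc2cc(-c3ccccc3)oc12` gives 5.01 nM. Compound 3 `Cc1cc(NC(=O)CC2CCNCC2)nn1Cc1cc(Cl)cc2cc(-c3ccccc3)oc12` gives 63.1 nM, the highest number of the three: it stands a 6.3-fold higher number from compound 1 to compound 3 (0.80 log units; beyond the scatter) and a 13-fold higher number from compound 2 to compound 3 (1.10 log units; beyond the scatter), while the step of a 2.0-fold lower number from compound 1 to compound 2 (0.30 log units; within the scatter) is within the scatter.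

Compound 4 `Cc1cc(NC(=O)C2(F)CCNCC2)nn1Cc1cc(Cl)cc2cc(-c3ccccc3)oc12` is not yet measured. It differs from compound 3 by 4-fluoropiperidin-4-yl in place of (piperidin-4-yl)methyl on a carbonyl carbon. Within the data shown here, no measured step covers this exchange; the two steps that lead into compound 3 both swap the whole side group for a different amide type, and nothing in the set varies the piperidine part on its own. Both of those steps were modest to large, but they concern the connection of the side group to the core, which compound 4 keeps unchanged.

Among the measured compounds shown here, with no direct precedent, the expectation for compound 4 in this assay is a number close to that of compound 3, with the change a 1.1-fold higher number from compound 3 to compound 4 (0.05 log units; within the scatter) expected to lie within the scatter. The estimate for compound 4 is 70 nM, in the expected range 25 nM to 200 nM.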

Compound 4, half-maximal inhibitory concentration: 39.8 nM
Beside the measured number, compound 4's estimate is 1.8-fold (0.25 log units) above it; low and high end bracket the measured number.
By their numbers in this assay, from the lowest: compounds 2 and 1 (each within the scatter of the next); then compounds 4 and 3 (each within the scatter of the next).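

Working notes, continued. In this assay, among these compounds, the exchange of (piperidin-4-yl)methyl for 4-fluoropiperidin-4-yl on the carbonyl carbon is the first variation within the side group itself, and it leaves the two compounds within the scatter of each other (a 1.6-fold lower number from compound 3 to compound 4 (0.20 log units; within the scatter)), so this change, which adds fluorine and shortens the link to the ring at once, does not separate them in this assay. The gap to the two smaller amides, first seen with compound 3, is also present for the fluorinated compound, both steps lying beyond the scatter (a 7.9-fold higher number from compound 2 to compound 4 (0.90 log units; beyond the scatter); a 4.0-fold higher number from compound 1 to compound 4 (0.60 log units; beyond the scatter)), so across these compounds it tracks the change to the larger side group rather than the detail within the piperidine. Nothing available bears on the reason for any of these steps.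

Still open, going by these compounds, is how a plain piperidin-4-yl group on the same carbonyl carbon would read, which would separate the effect of the fluorine from that of the shorter link. Also open, on these data alone, is whether the ring amine matters at all, a question that an N-methylpiperidine, a cyclohexyl group or a tetrahydropyranyl group in its place could address.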